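The source may report more compounds than this note shows. Statements on the series, on what has been measured and on what is new or still open speak of the compounds shown alone.

Measured so far, in a functional assay on NCI-H460 cells (Homo sapiens) for antiproliferative activity, read by CCK-8 assay, with a stated time of 72 h, tested at 8 uM; a higher number here means a stronger effect of the compound at the concentration tested, a lower number a weaker effect:
compound 1 `CC(C)n1cnc2c(Nc3ccccc3)nc(NCOCc3ccc(C(=O)Nc4ccccc4N)cc3)nc21`: 34.3%
compound 2 `CC(C)n1cnc2c(Nc3ccccc3)nc(NCOCc3ccc(/C=C/C(=O)Nc4ccccc4N)cc3)nc21`: 53.1%
compound 3 `CCCCn1cnc2c(NCc3ccc(C(=O)Nc4ccccc4N)cc3)nc(Cl)nc21`: 23.7%

Among these three numbers compound 2 stands highest. The nearest number belongs to compound 1, and a number 18.8 percentage points higher from compound 1 to compound 2 (beyond the scatter) lies beyond the scatter; compound 3 sits furthest away, its value also beyond the scatter below that of compound 2.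

Compound 4 `CC(C)n1cnc2c(Nc3cccc(Cl)c3)nc(NCOCc3ccc(/C=C/C(=O)Nc4ccccc4N)cc3)nc21` has not yet been measured. It differs from compound 2 in a single place: chloro in place of hydrogen on an aromatic carbon. Among the compounds with values here, no measured step speaks to this kind of change. Within the data shown here, the only step seen so far, a number 18.8 percentage points higher from compound 1 to compound 2 (beyond the scatter), concerns a different part of the molecule and says nothing about chloro in place of hydrogen on an aromatic carbon of the phenyl ring. With nothing pointing in either direction, the expected step in this assay is none beyond the scatter, that is a number 1.9 percentage points higher from compound 2 to compound 4 (within the scatter). Compound 4 is therefore estimated at 55%, with a range from 35% to 75%.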

Compound 4, a percentage reported as inhibition, at one concentration (the size of the read-out at that concentration, not a potency): 61.1%
The estimate for compound 4 lay 6.1 percentage points below the measured number; low and high end bracket the measured number.
By their numbers in this assay, from the lowest: compound 3; then compound 1; then compounds 2 and 4 (each within the scatter of the next).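

In this assay, 3-chlorophenyl in place of phenyl gives a number 8 percentage points higher from compound 2 to compound 4 (within the scatter). This is the first change shown on this ring, since the earlier step concerned a different part of the molecule, and it shows that a chloro at this position on the ring leaves the read-out within the usual scatter, so neither a gain nor a loss can be claimed. No measurement shown here bears on why the chloro has so little effect.

Still open, from the compounds shown here alone, is whether a different group at this position, such as methoxy, methyl, fluoro or an amine, would shift the read-out beyond the scatter. Also open, going by these compounds, is whether a chloro on another carbon of this ring would behave as it does here, and whether the same change would give a similar result on the shared core of compound 1.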